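The compounds below may be only part of what the source reports. "The series", "measured", "known", "first", "only" and "open" are said of these compounds alone.

In an ADME assay on BHK-21 cells (Mesocricetus auratus) for cytotoxicity, read by MTT assay (a higher number here means that more compound is tolerated, a lower number that less compound is tolerated), compound 1 `C/C(=N\NC(N)=S)c1ccc2[nH]c(-c3ccc(Cl)cc3)nc2c1` gives > 100000 nM, which is a limit and not a number. Compound 2 `CC(=O)c1ccc2c(c1)nc(-c1ccc(Cl)cc1)n2C1CCCCC1` gives > 100000 nM, also a limit. Compound 3 `C/C(=N\NC(N)=S)c1ccc2c(c1)nc(-c1ccc(Cl)cc1)n2C1CCCCC1` gives > 100000 nM, again a limit. Compound 4 `C/C(=N\NC(N)=S)c1ccc2c(c1)nc(-c1ccccn1)n2C1CCCCC1` is unmeasured and differs from compound 3 by pyridin-2-yl in place of 4-chlorophenyl on an aromatic carbon. Pyridin-2-yl stands in place of 4-chlorophenyl, a swap that neither measured step makes. Those steps, a step that the two limits leave unreadable from compound 1 to compound 3 and a step that the two limits leave unreadable from compound 2 to compound 3, have no readable size. What remains is that compound 3 sits on (the limit of > 100000 nM in this assay, at which 3 of the 3 values shown sit), so no step beyond the scatter is expected in this assay. The expected step is an at least 1.1-fold lower number from compound 3 to compound 4 (0.04 log units; that floor lies within the scatter). For compound 4 the estimated value is 90000 nM, expected to fall between 35000 nM and 150000 nM.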

Compound 4, half-maximal cytotoxic concentration: 24000 nM
The estimate for compound 4 lay 3.8-fold (0.57 log units) above the measured number; the whole stated range lies above it.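

In this assay, pyridin-2-yl in place of 4-chlorophenyl gives an at least 4.1-fold lower number from compound 3 to compound 4 (0.61 log units; beyond the scatter), so this aromatic carbon is a place where a change can make the compound less tolerated. The earlier steps cannot be read, and compound 4 is the first compound here with a real number, the others resting on one limit: the limit of > 100000 nM in this assay, at which 3 of the 4 values shown sit.

A plain phenyl group at this place would help separate losing the chlorine from gaining the ring nitrogen. On these data alone, whether a 4-aminophenyl group would be tolerated like 4-chlorophenyl or like pyridin-2-yl stays open.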